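Chloro in place of methyl on compound 2

The source may hold more compounds than are shown below. What is called first, only, known or untested is meant among the compounds shown, and "the series" means these compounds.

Compound 1 `Cc1cccc(NNC(=O)c2ccc(NS(=O)(=O)c3cnc(O)nc3O)cc2)c1` - > 20000 nM
Compound 2 `Cc1ccccc1NNC(=O)c1cccc(NS(=O)(=O)c2cnc(O)nc2O)c1` - 14200 nM

Both compounds were run in a functional assay on A549 cells (Homo sapiens) for antiproliferative activity, read by MTT assay, with a stated time of 24 h (on this read-out higher numbers stand for weaker inhibition and lower numbers for stronger inhibition), and their values come from it. For compound 1 the value > 20000 nM is a limit of the assay and not a number. Among the measured compounds shown here, compound 2 at 14200 nM holds the only actual number so far, so it stands alone, with no measured step to compare it against.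

Compound 3 `O=C(NNc1ccccc1Cl)c1cccc(NS(=O)(=O)c2cnc(O)nc2O)c1` differs from compound 2 in one place: chloro in place of methyl on an aromatic carbon describes it, chloro in place of methyl on an aromatic carbon, ortho to a large group. Nothing measured yet sizes this swap. With compound 2 at 14200 nM as the starting point, this exchange of one group is expected to leave the result in this assay little changed, with a step no larger than the usual scatter and no clear direction. The estimated change is a 1.2-fold lower number from compound 2 to compound 3 (0.07 log units; within the scatter) and it stays inside that scatter. Compound 3 is estimated at 12000 nM with an expected range from 6000 nM to 20000 nM in this read-out.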

Compound 3, half-maximal inhibitory concentration: 1460 nM
The estimate for compound 3 lay 8.2-fold (0.91 log units) above the measured number, and the stated range ends above it.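

The position on the 2-methylphenyl group clearly matters in this assay: chloro in place of methyl on this aromatic carbon, ortho to a large group, gives a 9.7-fold lower number from compound 2 to compound 3 (0.99 log units; beyond the scatter) for this single exchange. Among the compounds shown here, this is the first measured step here, and it lies beyond the usual scatter, so replacing one heavy atom with another, with no hydrogen-bond donor or acceptor entering or leaving, is enough to change the result clearly. Nothing measured among the compounds shown accounts for the size of this step.

Going by these compounds, whether fluoro, bromo or methoxy at this place would give a similar step stays open. On these data alone, it is also open whether chloro would give such a step at other places on this ring, or on a different core.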